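Short half-lives across a bromobenzyl urea series

A few compounds are considered here, and "the series" means these few. Any claim that something is new, unique, unknown or untested is made for them only; others in the source may bear on it.

Three compounds on the shared core of compound 1 `O=C(NCc1ccccc1Br)N1C(=O)c2ccccc2S1(=O)=O` have been measured in a physicochemical assay for pharmacokinetics; on this read-out higher numbers stand for a longer-lived compound and lower numbers for a shorter-lived compound. Compound 1 gives 0.253 h. Compound 2 `O=C(NCc1cccc(Br)c1)N1C(=O)c2ccccc2S1(=O)=O` gives 0.492 h, and compound 3 `O=C(NCc1ccccc1Cl)N1C(=O)c2ccccc2S1(=O)=O` gives 0.42 h. The number for compound 1 is the lowest of the three, yet both steps away from it are small: a 1.9-fold higher number from compound 1 to compound 2 (0.29 log units; within the scatter), and a 1.7-fold higher number from compound 1 to compound 3 (0.22 log units; within the scatter). Between compound 2 and compound 3 the gap is also small, a 1.2-fold lower number from compound 2 to compound 3 (0.07 log units; within the scatter).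

Compound 4 `COc1ccccc1CNC(=O)N1C(=O)c2ccccc2S1(=O)=O` is not yet measured in this assay. It differs from compound 1 by methoxy in place of bromo on an aromatic carbon. For the measured compounds named here, the closest precedent is the step from compound 1 to compound 3, a change of the group on the same aromatic carbon, which stayed within the scatter. Going by the values given here, no measured step leaves the scatter, so no step beyond it is expected here either; the estimated step is a 1.4-fold higher number from compound 1 to compound 4 (0.14 log units; within the scatter). Compound 4 is therefore expected to give about 0.35 h, within roughly 0.15 h to 0.85 h.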

Compound 4, half-life: 1.12 h
For compound 4 the middle estimate is 3.2-fold (0.51 log units) below the measured one, and the stated range ends below it.
By their numbers in this assay, from the lowest: compounds 1, 3 and 2 (each within the scatter of the next); then compound 4.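

In this assay the group on this aromatic carbon, ortho to a large group, proves able to move the number: methoxy in place of bromo gives a clear step (a 4.4-fold higher number from compound 1 to compound 4 (0.65 log units; beyond the scatter)), and methoxy in place of chloro gives another (a 2.7-fold higher number from compound 3 to compound 4 (0.43 log units; beyond the scatter)), whereas chloro in place of bromo at the same place stayed within the scatter. The 2-methoxyphenyl group also stands apart from the 3-bromophenyl group (a 2.3-fold higher number from compound 2 to compound 4 (0.36 log units; beyond the scatter)), so compound 4 is separated from all three halogen compounds, which remain within the scatter of one another. No measurement at hand bears on why the methoxy compound gives the higher number.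

Going by these compounds, whether this step belongs to methoxy alone stays open. A hydroxyl, an ethoxy or a dimethylamino group on the same carbon would test how far it extends.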